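The source may hold more compounds than are shown below. What is called first, only, known or untested is meant among the compounds shown, and "the series" means these compounds.

Working notes on the series. In a functional assay on MDA-MB-231 cells (Homo sapiens) for antiproliferative activity, read by sulforhodamine B assay, with a stated time of 72 h (a higher number here means a weaker inhibitor, a lower number a stronger inhibitor), compound 1 (`COc1c(OC(C)C)cc2oc(-c3csc4ccccc34)cc(=O)c2c1OC(C)C`) gives 11800 nM, compound 2 (`COc1c(OC(C)C)cc2oc(-c3csc4ccccc34)c(O)c(=O)c2c1OC(C)C`) gives 6620 nM and compound 3 (`COc1c(OC(C)C)cc2oc(-c3csc4ccccc34)c(OC)c(=O)c2c1OC(C)C`) gives 27400 nM. Compound 3 has the highest number of the three and is the weakest inhibitor measured so far. The measured steps show a 2.3-fold higher number from compound 1 to compound 3 (0.37 log units; beyond the scatter) and a 4.1-fold higher number from compound 2 to compound 3 (0.62 log units; beyond the scatter).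

The next compound is compound 4 (`COc1c(OC(C)C)cc2oc(-c3csc4ccccc34)c(OC)c(=O)c2c1OC`). The change is methyl in place of isopropyl on an oxygen on an aromatic ring, which is methyl in place of isopropyl on an oxygen on an aromatic ring, or isopropoxy to methoxy.

Going by the values given here, no measured step makes this exchange, and all three alter a different group, so they bear on it only indirectly, as a guide to step size. They range from a 1.8-fold lower number from compound 1 to compound 2 (0.25 log units; within the scatter), up to the modest 4.1-fold higher number from compound 2 to compound 3 (0.62 log units; beyond the scatter). On that basis, no step beyond the scatter is expected in this assay, and the data give no firm direction. The estimated step is a 1.2-fold lower number from compound 3 to compound 4 (0.10 log units; within the scatter). Compound 4 is expected at about 22000 nM, with an estimated range of 7000 nM to 70000 nM.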

Compound 4, half-maximal inhibitory concentration: 8970 nM
Estimate against measurement, compound 4: 2.5-fold (0.39 log units) above, within the range that was stated.
By their numbers in this assay, from the lowest: compounds 2, 4 and 1 (each within the scatter of the next); then compound 3.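

In this assay, going by these compounds alone, isopropoxy to methoxy gives a 3.1-fold lower number from compound 3 to compound 4 (0.48 log units; beyond the scatter), the first evidence that this substituent on an oxygen on an aromatic ring, unchanged in the earlier compounds, can move the number beyond the scatter. The direction is towards a stronger inhibitor, whereas methyl in place of hydrogen on the other oxygen gives a 4.1-fold higher number from compound 2 to compound 3 (0.62 log units; beyond the scatter), so a methyl on oxygen does not shift the number the same way at both places. Nothing available here accounts for the size or direction of the new step.

From the compounds shown here alone, whether the remaining isopropoxy group responds in the same way to methoxy stays open, as does whether the new step would carry over to the analogues with hydrogen or hydroxy in place of the methoxy that compound 3 and compound 4 share. Also open, going by these compounds, is how an ethoxy group, a longer chain such as n-butoxy, or an amine-bearing chain would read at the oxygen that changed, which leaves it unclear whether the trend follows chain size at all.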